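Indole series: swapping the ester for a nitrile

The source may report more compounds than this note shows. Statements on the series, on what has been measured and on what is new or still open speak of the compounds shown alone.

Compound 1 `CCOC(=O)c1c(NC(C)c2ccccc2)[nH]c2ccc(O)cc12` gives 3000 nM in an assay on isolated protein for inhibition of Polyunsaturated fatty acid 5-lipoxygenase (Homo sapiens) (a lower number here means a stronger inhibitor, a higher number a weaker inhibitor), the second highest of the three numbers in hand. Compound 2 `CCOC(=O)c1c(Nc2cccc(Cl)c2)[nH]c2ccc(O)cc12` gives 300 nM in this assay, and compound 3 `CCOC(=O)c1c(NC(C)c2ccccc2)[nH]c2ccccc12` gives 9800 nM. The two measured steps are a 10-fold lower number from compound 1 to compound 2 (1.00 log units; beyond the scatter) and a 3.3-fold higher number from compound 1 to compound 3 (0.51 log units; beyond the scatter); both alter other parts of the shared core of compound 1 and leave the ethoxycarbonyl untouched, so neither bears directly on the change to compound 4 `CC(Nc1[nH]c2ccc(O)cc2c1C#N)c1ccccc1`, which is cyano in place of ethoxycarbonyl on an aromatic carbon. Within the data shown here, with no measured step at this position, the direction of the effect cannot be read from the series; the modest sizes of the two known steps suggest a step of comparable scale is plausible, in either direction, and a result within the scatter cannot be ruled out. The expectation for compound 4 is therefore a number close to that of compound 1, with a wide range, written as a 1.3-fold higher number from compound 1 to compound 4 (0.12 log units; within the scatter). Compound 4 is estimated at 4000 nM, expected between 1000 nM and 16000 nM.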

Compound 4, half-maximal inhibitory concentration: 10000 nM
Compound 4: the middle estimate sits 2.5-fold (0.40 log units) below what was measured; measured number inside the range.
By their numbers in this assay, from the lowest: compound 2; then compound 1; then compounds 3 and 4 (each within the scatter of the next).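

In this assay, among these compounds, the change at this aromatic carbon gives a 3.3-fold higher number from compound 1 to compound 4 (0.52 log units; beyond the scatter), so a position left untouched in the earlier compounds does respond to the group placed on it. On the core of compound 1, ethoxycarbonyl gives the stronger inhibitor of the two groups compared, and cyano offers no gain here. Nothing in hand explains this difference.

From the compounds shown here alone, it remains open whether a carboxylic acid, a primary amide or a longer ester such as butoxycarbonyl on this carbon would match ethoxycarbonyl or fall closer to cyano. Also open, going by these compounds, is whether cyano in place of ethoxycarbonyl would have a similar effect with the 3-chlorophenyl group of compound 2, which gives 300 nM.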